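Compound 4 and the step from compound 2

The source may hold more compounds than are shown below. What is called first, only, known or untested is meant among the compounds shown, and "the series" means these compounds.

compound 1 `Cc1nnc(NC(=O)C(C)Sc2nc3ccccc3n2-c2ccc(F)cc2)nc1C` - "not determined" (no result reported)
compound 2 `COc1ccc(-n2c(SC(C)C(=O)Nc3nnc(C)c(C)n3)nc3ccccc32)cc1` - "not determined" (no result reported)
compound 3 `COc1ccc(-n2c([S+]([O-])C(C)C(=O)Nc3ccc(C)cc3Cl)nc3ccccc32)cc1` - > 75000 nM

In an ADME assay on Vero cells (Chlorocebus sabaeus) for cytotoxicity, read by MTT assay, with a stated time of 24 h (a higher number here means that more compound is tolerated, a lower number that less compound is tolerated), compound 2 has no single number, and its entry reads "not determined" (no result reported) without any result behind it. Compound 1 is in the same position, with "not determined" (no result reported) as its entry. Compound 3 gives > 75000 nM in this assay and this is a limit of the assay, not a number. Among the measured compounds shown here, compound 2 therefore offers no measured starting point, and the series has no step between measured compounds to serve as a yardstick.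

Compound 4 `COc1ccc(-n2c(SC(C)C(=O)Nc3cc(C)nn3C)nc3ccccc32)cc1` has yet to be measured in this assay. The change is 1,3-dimethyl-1H-pyrazol-5-yl in place of 5,6-dimethyl-1,2,4-triazin-3-yl on an amide-type nitrogen. With nothing measured to size such a change, no shift beyond the usual scatter is expected, in either direction. For the measured compounds named here, the only reading that can guide an expectation is the limit of compound 3 at > 75000 nM in this assay, so a high tolerated concentration is expected here too, quite possibly reported only as a limit. The estimated half-maximal cytotoxic concentration of compound 4 is 100000 nM (expected range 40000 nM to 300000 nM).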

Compound 4, half-maximal cytotoxic concentration: 75000 nM
The estimate for compound 4 lay 1.3-fold (0.12 log units) above the measured number; the measured number falls inside the stated range.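

No new step can be read from compound 4, since compound 2, which differs from it in one place, has no number in this assay to compare with. The compounds shown leave open what 1,3-dimethyl-1H-pyrazol-5-yl in place of 5,6-dimethyl-1,2,4-triazin-3-yl does to the tolerated concentration, and how much of the series can be told apart at all: the limit of > 75000 nM in this assay, at which 1 of the 4 values shown sits.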